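This account rests on a few compounds, and the source may have more. Where it says the series, first, only, none or still open, it means among the compounds named here.

Compound 1 `Cc1ncc([N+](=O)[O-])n1CCSc1nnc(-c2ccccc2)o1`: 30100 nM
Compound 2 `Cc1ccccc1-c1nnc(SCCn2c([N+](=O)[O-])cnc2C)o1`: 32300 nM
Compound 3 `Cc1ncc([N+](=O)[O-])n1CCSc1nnc(-c2ccccc2Cl)o1`: 32600 nM

In a functional assay on SGC-7901 cells (Homo sapiens) for cytotoxicity, read by MTT assay, with a stated time of 48 h (a higher number here means a weaker inhibitor, a lower number a stronger inhibitor), compound 3 stands level with the other two, as a 1.1-fold higher number from compound 1 to compound 3 (0.03 log units; within the scatter) and a 1.0-fold higher number from compound 2 to compound 3 (0.00 log units; within the scatter) show. Compound 4 `Cc1cccc(-c2nnc(SCCn3c([N+](=O)[O-])cnc3C)o2)c1O` carries 2-hydroxy-3-methylphenyl in place of 2-chlorophenyl (2-hydroxy-3-methylphenyl in place of 2-chlorophenyl on an aromatic carbon). Among the compounds with values here, the steps that bear on this change are a 1.1-fold higher number from compound 1 to compound 2 (0.03 log units; within the scatter), which adds methyl, and a 1.1-fold higher number from compound 1 to compound 3 (0.03 log units; within the scatter), which adds chloro. Both are small and within the scatter. Within the data shown here, no measured compound carries a hydroxy group, so that part of the change is untested. No step beyond the scatter is therefore expected in this assay, though the uncertainty is wide. The expected change is a 1.3-fold lower number from compound 3 to compound 4 (0.12 log units; within the scatter). For compound 4 the estimated value is 25000 nM, with an expected range of 9000 nM to 50000 nM.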

Compound 4, half-maximal inhibitory concentration: 35900 nM
Compound 4: the middle estimate sits 1.4-fold (0.16 log units) below what was measured; the range from low to high includes it.
By their numbers in this assay, from the lowest: compounds 1, 2, 3 and 4 (each within the scatter of the next).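

In this assay, the first hydroxy group tested at this position gives no step beyond the scatter against any earlier compound (a 1.1-fold higher number from compound 3 to compound 4 (0.04 log units; within the scatter)), (a 1.1-fold higher number from compound 2 to compound 4 (0.05 log units; within the scatter)), (a 1.2-fold higher number from compound 1 to compound 4 (0.08 log units; within the scatter)). So 2-hydroxy-3-methylphenyl, with its hydrogen-bond donor, reads the same here as 2-chlorophenyl, 2-methylphenyl and phenyl, which have none. Nothing available accounts for this sameness. As far as these compounds go, whether an amine or a carboxylic acid on the phenyl ring would give a step beyond the scatter stays open. So does the effect of a longer chain at this position.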